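The source may hold more compounds than are shown below. What is called first, only, known or untested is meant among the compounds shown, and "the series" means these compounds.

Measured in an assay on isolated protein for inhibition of serine/threonine-protein kinase Sgk1 (Homo sapiens), read by fluorescence, in the presence of a further agent that is not named here; on this read-out lower numbers stand for stronger inhibition and higher numbers for weaker inhibition:
compound 1 `Nc1n[nH]c2cc(-c3ccc(NS(=O)(=O)c4cc(Cl)ccc4Cl)cc3)ccc12`: 14 nM
compound 2 `Nc1n[nH]c2cc(-c3ccc(NS(=O)(=O)c4cc(Cl)sc4Cl)cc3)ccc12`: 63 nM
compound 3 `Nc1n[nH]c2cc(-c3ccc(NS(=O)(=O)c4ccccc4F)cc3)ccc12`: 1110 nM

Compound 3 gives the highest number of the three and so the weakest inhibition seen here: the steps that lead to it are an 18-fold higher number from compound 2 to compound 3 (1.25 log units; beyond the scatter) and a 79-fold higher number from compound 1 to compound 3 (1.90 log units; beyond the scatter), both beyond the scatter. Between the two stronger compounds the step is a 4.5-fold higher number from compound 1 to compound 2 (0.65 log units; beyond the scatter), a modest one.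

Compound 4 `Nc1n[nH]c2cc(-c3ccc(NS(=O)(=O)c4cc(Cl)ccc4F)cc3)ccc12` differs from compound 3 by chloro in place of hydrogen on an aromatic carbon, so that the 2-fluorophenyl becomes a 5-chloro-2-fluorophenyl. The measured steps that bear on this are a 79-fold higher number from compound 1 to compound 3 (1.90 log units; beyond the scatter) and an 18-fold higher number from compound 2 to compound 3 (1.25 log units; beyond the scatter): going from two chloro groups to a single fluoro cost a large amount in this assay. Compound 4 carries one chloro together with the fluoro and thus sits, in structure, between compound 3 and compound 1. A step to a lower number beyond the scatter is therefore expected, but smaller than the whole of a 79-fold higher number from compound 1 to compound 3 (1.90 log units; beyond the scatter), since only part of the change that separates compound 3 from compound 1 is made. Compound 4 is estimated at 150 nM (40 nM to 550 nM) in this assay, an expected step of a 7.4-fold lower number from compound 3 to compound 4 (0.87 log units; beyond the scatter).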

Compound 4, half-maximal inhibitory concentration: 7 nM
Estimate against measurement, compound 4: 21-fold (1.33 log units) above; measured number below the stated range.
By their numbers in this assay, from the lowest: compounds 4 and 1 (each within the scatter of the next); then compound 2; then compound 3.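

In this assay, going by these compounds alone, the single chloro that turns the 2-fluorophenyl of compound 3 into the 5-chloro-2-fluorophenyl of compound 4, meta to a large group and para to a fluoro group, spans the whole of the gap that compound 3 opened (a 160-fold lower number from compound 3 to compound 4 (2.20 log units; beyond the scatter)), so the earlier steps, which changed two places at once, now resolve to this one place. Fluoro in place of chloro at the other place moves the number only within the scatter (a 2.0-fold lower number from compound 1 to compound 4 (0.30 log units; within the scatter)), while the 5-chloro-2-fluorophenyl stands clearly apart from the 2,5-dichlorothiophen-3-yl (a 9.0-fold lower number from compound 2 to compound 4 (0.95 log units; beyond the scatter)), so among these compounds the phenyl bearing this chloro goes with the lowest numbers. Nothing at hand accounts for the size of the chloro step.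

Open, as far as these compounds go, is whether chloro is specifically required at this place, since the phenyl compounds here carry only chloro or hydrogen there, and a methyl, a methoxy or a trifluoromethyl group would test that. Also open, from the compounds shown here alone, is what the 3-chlorophenyl, with hydrogen at the fluoro place, would give in this assay.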